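Swapping a Pyrrole for a Cyclopentene Ring

The compounds below may be only part of what the source reports. "The series", "measured", "known", "first", "only" and "open" are said of these compounds alone.

Compound 1, `Cn1nc2c(=O)n(CC3(O)CCN(Cc4ccc(-c5n[nH]c(=O)o5)cc4Cl)CC3)cnc2c1-c1ccc(CN)cc1`, in an assay on isolated protein for inhibition of ubiquitin carboxyl-terminal hydrolase 7 (Homo sapiens), with stated times of 30 min and 2 h; on this read-out higher numbers stand for weaker inhibition and lower numbers for stronger inhibition: 171 nM
Compound 2, `Cn1nc2c(=O)n(CC3(O)CCN(Cc4ccc(-c5ccc[nH]5)cc4Cl)CC3)cnc2c1-c1ccc(CN)cc1`, in this assay: 193 nM

Compound 2 has the highest of the two numbers, but the step of a 1.1-fold higher number from compound 1 to compound 2 (0.05 log units; within the scatter) shows that this is within the scatter, so neither compound can be called stronger than the other. Among the compounds with values here, the one measured step swaps one five-membered aromatic ring for another on the same aromatic carbon and changes little. Compound 3, `Cn1nc2c(=O)n(CC3(O)CCN(Cc4ccc(C5=CCCC5)cc4Cl)CC3)cnc2c1-c1ccc(CN)cc1`, carries cyclopent-1-en-1-yl in place of 1H-pyrrol-2-yl on an aromatic carbon. Within the data shown here, no measured pair removes the hydrogen-bond donor in this way, so the only guide is that the earlier change at this carbon stayed flat. A step near that size is expected, perhaps slightly toward weaker inhibition: a 1.3-fold higher number from compound 2 to compound 3 (0.13 log units; within the scatter). Compound 3 is therefore estimated at 260 nM, with a range from 100 nM to 700 nM.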

Compound 3, half-maximal inhibitory concentration: 76.9 nM
Compound 3: the middle estimate sits 3.4-fold (0.53 log units) above what was measured, outside the stated range (below it).
By their numbers in this assay, from the lowest: compound 3; then compounds 1 and 2 (each within the scatter of the next).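

In this assay the change from 1H-pyrrol-2-yl to cyclopent-1-en-1-yl gives a 2.5-fold lower number from compound 2 to compound 3 (0.40 log units; beyond the scatter) and the change from the ring with 3 hetero atoms gives a 2.2-fold lower number from compound 1 to compound 3 (0.35 log units; beyond the scatter) so this position responds to the group placed on it, which the two earlier compounds, within the scatter of each other, did not show. Neither an aromatic ring nor a hetero atom in the ring is required here for inhibition at this level. Compound 3 has the lowest number of the three with a ring of carbon only and 0 hydrogen-bond donors.

Going by these compounds, the part played by the ring's double bond stays open, and a saturated cyclopentyl ring or a phenyl ring at the same carbon would bear on it. The data shown offer no measurement that accounts for the gain.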